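Piperidine substituent variation on the shared core

A few compounds are considered here, and "the series" means these few. Any claim that something is new, unique, unknown or untested is made for them only; others in the source may bear on it.

Measured compounds in a functional assay on CHO-K1 cells for antagonist activity at transient receptor potential cation channel subfamily V member 1 (Homo sapiens), read by FLIPR; on this read-out higher numbers stand for weaker inhibition and lower numbers for stronger inhibition:
- compound 1 `CC(C(=O)NCc1ccc(C(F)(F)F)nc1NC1CCCCC1)c1ccc(NS(C)(=O)=O)c(F)c1`: 260 nM
- compound 2 `CC(C(=O)NCc1ccc(C(F)(F)F)nc1N1CCC(Cc2ccc(F)c(F)c2)CC1)c1ccc(NS(C)(=O)=O)c(F)c1`: 30 nM
- compound 3 `CC(C(=O)NCc1ccc(C(F)(F)F)nc1N1CCC(C(F)(F)F)CC1)c1ccc(NS(C)(=O)=O)c(F)c1`: 31 nM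

Compound 3 stands close to compound 2 and well apart from compound 1. The replacement of cyclohexylamino on an aromatic carbon by 4-(trifluoromethyl)piperidin-1-yl gave an 8.4-fold lower number from compound 1 to compound 3 (0.92 log units; beyond the scatter); the exchange on the saturated ring carbon, trifluoromethyl in place of 3,4-difluorobenzyl, gave a 1.0-fold higher number from compound 2 to compound 3 (0.01 log units; within the scatter).

Compound 4 `CCCCOC1CCN(c2nc(C(F)(F)F)ccc2CNC(=O)C(C)c2ccc(NS(C)(=O)=O)c(F)c2)CC1` differs from compound 3 by butoxy in place of trifluoromethyl on a saturated ring carbon. Within the data shown here, only the step from compound 2 to compound 3 touches this position, and it was flat, so two quite different groups on that saturated ring carbon gave the same number in this assay. The step from compound 1 to compound 3 concerns another site and does not bear on the butoxy change. The expected step is therefore a 1.3-fold higher number from compound 3 to compound 4 (0.11 log units; within the scatter), none beyond the scatter. Among the measured compounds shown here, compound 4 is estimated at 40 nM in this assay, with a range of 12 nM to 130 nM, the width reflecting that only one example at this position exists.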

Compound 4, half-maximal inhibitory concentration: 28.2 nM
The estimate for compound 4 lay 1.4-fold (0.15 log units) above the measured number, and the stated range covers the measured number.
By their numbers in this assay, from the lowest: compounds 4, 2 and 3 (each within the scatter of the next); then compound 1.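

Butoxy, which carries a hydrogen-bond acceptor where trifluoromethyl has none, leaves the number in place in this assay: the results are a 1.1-fold lower number from compound 3 to compound 4 (0.04 log units; within the scatter) and a 1.1-fold lower number from compound 2 to compound 4 (0.03 log units; within the scatter). A third, open-chain group on this saturated ring carbon therefore joins trifluoromethyl and 3,4-difluorobenzyl at one level, and the flatness no longer rests on a single pair. The separation from the cyclohexylamino compound also persists with butoxy, at a 9.2-fold lower number from compound 1 to compound 4 (0.96 log units; beyond the scatter). No measurement is available to explain why these groups give matching numbers.

Going by these compounds, whether an amine or a carboxylic acid on this saturated ring carbon would keep the number at the same level stays open. So does the outcome with only hydrogen at that carbon, or with a chain longer than butoxy.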